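The compounds below may be only part of what the source reports. "The series", "measured", "known", "first", "only" and "open" are said of these compounds alone.

Compound 3, with the structure `COc1cc(C)cc(-c2nn(CC#N)cc2-c2ccnc(-c3ccc(N(C)C)cc3)c2)c1`, was tested in a functional assay on NCI-H226 cells (Homo sapiens) for cytotoxicity, read by sulforhodamine B assay, with a stated time of 48 h, tested at 10 uM (a lower number here means a stronger effect, a higher number a weaker effect of the compound at the concentration tested), where it gives -22%. Among the three measured compounds it stands second highest. Compound 2, with the structure `Cc1cc(O)cc(-c2nn(CC#N)cc2-c2ccnc(-c3ccc(Oc4ccccc4)cc3)c2)c1`, gives -63% in this assay, a number well beyond the scatter below compound 3. Compound 1, with the structure `COc1cc(C)cc(-c2c(-c3ccnc(-c4ccc(C(C)=O)cc4)c3)cnn2CC#N)c1`, gives 35% in this assay, a number beyond the scatter above compound 3. Compound 2 differs from compound 3 in more than one place, so its value cannot be tied to any single change.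

Compound 4, with the structure `Cc1cc(O)cc(-c2nn(CC#N)cc2-c2ccnc(-c3ccc(N(C)C)cc3)c2)c1`, has not yet been measured. It differs from compound 3 as follows: hydrogen in place of methyl on an oxygen on an aromatic ring. Among the measured compounds shown here, no measured pair in this set shows this change alone, so the size of its effect in this assay is unknown. With compound 2 carrying the hydroxy and giving -63%, a modest downward step is expected, though one possibly within the scatter. The step from compound 3 to compound 4 is expected to be a number 13 percentage points lower from compound 3 to compound 4 (beyond the scatter). Compound 4 is therefore estimated at -35%, within a range of -70% to 5% in this assay.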

Compound 4, a percentage reported as activity, at one concentration (the size of the read-out at that concentration, not a potency): -38%
Compound 4: the middle estimate sits 3 percentage points above what was measured; the range from low to high includes it.
By their numbers in this assay, from the lowest: compound 2; then compound 4; then compound 3; then compound 1.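

Exchanging methoxy for hydroxy on the 3-methoxy-5-methylphenyl group gives, in this assay, a number 16 percentage points lower from compound 3 to compound 4 (beyond the scatter), so this oxygen substituent alone shifts the read-out. With the hydroxy held in place, dimethylamino in place of phenoxy on the aromatic carbon gives a number 25 percentage points higher from compound 2 to compound 4 (beyond the scatter), which shows that the other end of the molecule also shifts the read-out by a modest step of its own. The evidence at hand offers no explanation for either step.

From the compounds shown here alone, it remains open whether an ethyl group or a longer chain on this oxygen would give a value closer to that of the methoxy or the hydroxy, and what an amine in place of the oxygen would do. Going by these compounds, it is also open whether the step from methoxy to hydroxy keeps its size when phenoxy replaces dimethylamino.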